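The compounds below may be only part of what the source reports. "The series", "measured", "known", "first", "only" and "open" are said of these compounds alone.

For the measured compounds named here, in a functional assay on HepG2 cells (Homo sapiens) for inhibition, read by MTT assay, with a stated time of 24 h (a higher number here means a weaker inhibitor, a lower number a stronger inhibitor), compound 2 `CCOC(=O)c1c(C)[nH]c(=O)c(C#N)c1-c1ccc([N+](=O)[O-])cc1` gives 21700 nM, the lowest of the two numbers so far; the nearest is compound 1 `CCOC(=O)c1c(C)[nH]c(=O)c(C#N)c1-c1ccc(OC)cc1`, which gives 51500 nM. Going by the values given here, the one measured step, a 2.4-fold lower number from compound 1 to compound 2 (0.38 log units; beyond the scatter), is the only guide to what a change at this aromatic carbon does. Compound 3 `CCOC(=O)c1c(C)[nH]c(=O)c(C#N)c1-c1ccc(C#N)cc1` differs from compound 2 by cyano in place of nitro on an aromatic carbon. Among the compounds with values here, no measured step replaces nitro by cyano, so a step of similar size to the one from compound 1 to compound 2, or none beyond the scatter, is expected, with the direction uncertain. For compound 3 the expected value in this assay is 28000 nM, with a range from 10000 nM to 80000 nM. That expectation amounts to a 1.3-fold higher number from compound 2 to compound 3 (0.11 log units; within the scatter).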

Compound 3, half-maximal inhibitory concentration: 20200 nM
Estimate against measurement, compound 3: 1.4-fold (0.14 log units) above; the measured number falls inside the stated range.
By their numbers in this assay, from the lowest: compounds 3 and 2 (each within the scatter of the next); then compound 1.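

In this assay, nitro and cyano cannot be told apart on this aromatic carbon, para to a large group, with a 1.1-fold lower number from compound 2 to compound 3 (0.03 log units; within the scatter) as the printed step. The second replacement of methoxy, a 2.5-fold lower number from compound 1 to compound 3 (0.41 log units; beyond the scatter), leaves compound 1 apart from both compound 2 and compound 3, so the separation from compound 1 now rests on two different groups. For the compounds shown here, no evidence on the compounds bears on this result. Going by these compounds, how an amine, a carboxylic acid or a longer alkoxy chain on this carbon would compare remains open, as does any change elsewhere on the shared core.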